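Enamine in place of methyl on the piperazine nitrogen

The compounds below may be only part of what the source reports. "The series", "measured", "known", "first", "only" and "open" are said of these compounds alone.

Compound 1 `Cn1ccnc1SCC(=O)Nc1ccc(-c2nc(-c3ccccc3)c(-c3ccccc3)n2C)cc1` and compound 2 `CN1CCN(CC(=O)Nc2ccc(-c3nc(-c4ccccc4)c(-c4ccccc4)n3C)cc2)CC1` share one core and differ only in the group on a saturated chain carbon bound to a carbonyl carbon. In a functional assay on MCF7 cells (Homo sapiens) for cytotoxicity, read by MTT assay, with a stated time of 24 h (a lower number here means a stronger inhibitor, a higher number a weaker inhibitor), compound 1 gives 46.5 ug/mL, and in the same assay compound 2 gives 76.5 ug/mL. Going by the values given here, the one step measured so far, a 1.6-fold higher number from compound 1 to compound 2 (0.22 log units; within the scatter), came with 4-methylpiperazin-1-yl in place of (1-methyl-1H-imidazol-2-yl)sulfanyl. Compound 2 holds the higher of the two numbers, but that gap is within the scatter, so the two compounds are not ordered by this assay.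

Compound 3 `CN(C)/C=C/N1CCN(CC(=O)Nc2ccc(-c3nc(-c4ccccc4)c(-c4ccccc4)n3C)cc2)CC1` carries 2-(dimethylamino)ethenyl in place of methyl on an amine nitrogen in a ring. Among the compounds with values here, no measured step bears on a substituent at this ring nitrogen; the only step available exchanged the entire terminal group and still stayed within the scatter. On that basis the expected step of a 1.1-fold lower number from compound 2 to compound 3 (0.04 log units; within the scatter) is none beyond the scatter. Compound 3 is therefore estimated at 70 ug/mL in this assay, with a range from 25 ug/mL to 200 ug/mL.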

Compound 3, half-maximal inhibitory concentration: 80 ug/mL
Beside the measured number, compound 3's estimate is 1.1-fold (0.06 log units) below it, within the range that was stated.
By their numbers in this assay, from the lowest: compounds 1, 2 and 3 (each within the scatter of the next).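

In this assay, going by these compounds alone, the change of methyl to 2-(dimethylamino)ethenyl on the amine nitrogen in the ring gives a 1.0-fold higher number from compound 2 to compound 3 (0.02 log units; within the scatter) and is the first step measured at this position. This position therefore accepts a group of 5 heavy atoms, with a double bond outside aromatic rings and a hydrogen-bond acceptor, without a shift beyond the scatter. The exchange of the whole terminal group also gives a 1.7-fold higher number from compound 1 to compound 3 (0.24 log units; within the scatter) and leaves the three compounds unseparated by this assay, while no measurement at hand offers an explanation for these numbers.

Open, on these data alone, is whether a bare hydrogen on this nitrogen, a carboxylic acid at the end of a longer chain, or an acetyl group there would produce a step beyond the scatter. Also open, as far as these compounds go, is whether changes on the shared core, such as a fluorine on one of its phenyl groups, would separate compounds that the terminal group has not.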